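The compounds below may be only part of what the source reports. "The series", "measured", "known", "first", "only" and "open" are said of these compounds alone.

In a functional assay on MCF7 cells (Homo sapiens) for antiproliferative activity, read by MTT assay, with a stated time of 48 h (a higher number here means a weaker inhibitor, a lower number a stronger inhibitor), compound 1 (`CCNCC(=O)Nc1cc(OC)ccc1C(=O)c1ccc2c(c1)C=CC(C)(C)O2`) gives 6310 nM and compound 2 (`COc1ccc(C(=O)c2cc(OC)c(OC)c(OC)c2)c(NC(=O)CO)c1`) gives 230 nM on the same read-out. Compound 2 therefore holds the lower of the two numbers, and its gap to compound 1 lies beyond the scatter.

Compound 3 (`CNCC(=O)Nc1cc(OC)ccc1C(=O)c1cc(OC)c(OC)c(OC)c1`) departs from compound 2 in one place: methylamino in place of hydroxy on a saturated chain carbon bound to a carbonyl carbon. Among the compounds with values here, no measured pair isolates this change. Compound 1 differs from compound 2 in more than one place, so the gap between those two cannot be read as a measure of this swap.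

With nothing to set a direction, no step beyond the scatter is expected in this assay for this change. The estimated move is a 1.5-fold higher number from compound 2 to compound 3 (0.18 log units; within the scatter) and is expected to stay within the usual spread of repeat measurements. For compound 3 the expected value is 350 nM with an estimated range from 80 nM to 1600 nM for repeated measurements.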

Compound 3, half-maximal inhibitory concentration: 550 nM
The estimate for compound 3 lay 1.6-fold (0.20 log units) below the measured number, within the range that was stated.
By their numbers in this assay, from the lowest: compound 2; then compound 3; then compound 1.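

In this assay the first pair differing in one place gives a 2.4-fold higher number from compound 2 to compound 3 (0.38 log units; beyond the scatter) for methylamino in place of hydroxy on a saturated chain carbon bound to a carbonyl carbon, a modest step beyond the scatter. This position therefore responds to the group it carries, and of these two groups hydroxy holds the lower number, even though both groups count the same hydrogen-bond donors and acceptors and neither has a net charge. No measurement among the data bears on what lies behind this step.

One step on one shared core leaves open whether the order of hydroxy and methylamino would hold on the core of compound 1, which differs from compound 2 and compound 3 in more than one place. It also leaves open how this position would respond to an unsubstituted amine, a dimethylamino group, a methoxy group, a carboxylic acid or a longer chain, and whether any of these would match or pass hydroxy.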